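The source may report more compounds than this note shows. Statements on the series, on what has been measured and on what is new or still open speak of the compounds shown alone.

Series notes. Compound 1 `COc1ccc(-c2cnc3scc(C(=O)NNC(C)=O)n23)cc1` gives 8360 nM in a functional assay on MCF7 cells (Homo sapiens) for antiproliferative activity, read by MTT assay, with a stated time of 72 h; a lower number here means a stronger inhibitor, a higher number a weaker inhibitor. Compound 2 `CCC(=O)NNC(=O)c1csc2ncc(-c3ccc(OC)cc3)n12` differs from compound 1 by methyl in place of hydrogen on a saturated chain carbon bound to a carbonyl carbon; in this assay compound 2 gives 53200 nM, and the step is a 6.4-fold higher number from compound 1 to compound 2 (0.80 log units; beyond the scatter). Compound 3 `CCC(=O)NNC(=O)c1csc2ncc(-c3ccc(Br)cc3)n12` keeps the propanoyl group of compound 2 and differs from it by bromo in place of methoxy on an aromatic carbon; in this assay compound 3 gives 15000 nM, the step being a 3.5-fold lower number from compound 2 to compound 3 (0.55 log units; beyond the scatter). Against compound 1, the difference between the two cores is not broken down here.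

Compound 4 `CCCC(=O)NNC(=O)c1csc2ncc(-c3ccc(Br)cc3)n12` is not yet measured. It differs from compound 3 by methyl in place of hydrogen on a saturated chain carbon, two bonds along the chain from a carbonyl carbon. This is the same kind of change as that between compound 1 and compound 2, not the same: there the entering methyl sat on a saturated chain carbon bound to a carbonyl carbon, here on a saturated chain carbon, two bonds along the chain from a carbonyl carbon. Because the earlier lengthening gave a 6.4-fold higher number from compound 1 to compound 2 (0.80 log units; beyond the scatter), a weakening step of about a 2.3-fold higher number from compound 3 to compound 4 (0.37 log units; beyond the scatter) is expected. Compound 4 is accordingly expected to give 35000 nM in this assay, within 12000 nM to 110000 nM. Going by the values given here, only one pair supports this expectation.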

Compound 4, half-maximal inhibitory concentration: 27500 nM
Beside the measured number, compound 4's estimate is 1.3-fold (0.10 log units) above it; low and high end bracket the measured number.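

Carrying this one-methyl lengthening from one core to another does not give a step of fixed size in this assay: the same change on two cores in this assay, a 6.4-fold higher number (0.80 log units; beyond the scatter) from compound 1 to compound 2 and a 1.8-fold higher number (0.26 log units; within the scatter) from compound 3 to compound 4, 3.5-fold (0.54 log units) apart, beyond the scatter of two such steps. The new step, a 1.8-fold higher number from compound 3 to compound 4 (0.26 log units; within the scatter), does not separate the two compounds, whereas the earlier step, a 6.4-fold higher number from compound 1 to compound 2 (0.80 log units; beyond the scatter), is a clear loss, so the earlier size cannot be read across to the core of compound 3. The two pairs differ in the aromatic substituent, methoxy in one and bromo in the other, and also in where the methyl enters. These two differences cannot be told apart from a single pair of each.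

Open, from the compounds shown here alone, is how an acetyl group would read on the core of compound 3, which would place both chain steps on a single core. Also open, going by these compounds, is whether a longer chain, or an amine in place of the propylcarbonyl chain, would shift the number on either core.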